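Butoxy for butyl on the pyridine-bearing amide

This account rests on a few compounds, and the source may have more. Where it says the series, first, only, none or still open, it means among the compounds named here.

Compound 2 `CCCCc1cccc(C(=O)Nc2nn[nH]n2)n1` is the weakest of the three compounds measured in a functional assay on the whole organism for inhibition, with Rattus norvegicus as the target, at a dose of 10 mg/kg by the oral route (on this read-out higher numbers stand for a stronger effect at the one dose given and lower numbers for a weaker effect), where compound 2 gives 18%. Compound 1 `O=C(Nc1nn[nH]n1)c1cccc(CCc2ccccc2)n1` gives 45%, and compound 3 `Cc1cccnc1C(=O)Nc1nn[nH]n1` gives 69%; both stand beyond the scatter above compound 2. For the measured compounds named here, the one step that alters the chain on the core is the change a number 27 percentage points lower from compound 1 to compound 2 (beyond the scatter), so shortening and simplifying that chain lowered the read-out by a modest amount.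

Compound 4 `CCCCOc1cccc(C(=O)Nc2nn[nH]n2)n1` differs from compound 2 by butoxy in place of butyl on an aromatic carbon. Going by the values given here, no measured pair shows a chain replaced by its oxygen-linked counterpart, so the only step that bears on the question is the one from compound 1 to compound 2, and it concerns a different change at the same chain. Among the compounds with values here, compound 3 carries a methyl on a core with the nitrogen placed otherwise, and no single step connects it to compound 2; its value only shows that small groups on this core can give high numbers.

Given the weak starting point of compound 2, compound 4 is expected to move by a number 7 percentage points higher from compound 2 to compound 4 (within the scatter), which is within the scatter. Compound 4 is therefore estimated at 25%, within a range from 5% to 50%.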

Compound 4, a percentage reported as inhibition, in the whole organism at one dose (the size of the read-out at that dose, not a potency): 8%
Estimate against measurement, compound 4: 17 percentage points above, and the stated range covers the measured number.
By their numbers in this assay, from the lowest: compounds 4 and 2 (each within the scatter of the next); then compound 1; then compound 3.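

Placing an oxygen between the shared core and the four-carbon chain, on the aromatic carbon next to the ring nitrogen, adds one hydrogen-bond acceptor but gives a step in this assay of a number 10 percentage points lower from compound 2 to compound 4 (within the scatter), so this read-out does not separate butoxy from butyl at this position. The earlier compounds shown here showed only that the read-out can respond to a change in the group on the chain: ethyl in place of phenyl gave a number 27 percentage points lower from compound 1 to compound 2 (beyond the scatter), whereas the new step shows that a change in the link to the aromatic carbon, with the four-carbon chain kept, gives no difference beyond the scatter. No measurement shown here gives a reason for this outcome.

On these data alone, it remains open whether the same oxygen link would leave the read-out unchanged on a chain ending in phenyl, where the starting number is higher, as only the butyl pair tests this change. An amine as the link at this position, or a carboxylic acid at the end of the chain, also stands outside what these compounds can tell.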